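The source may report more compounds than this note shows. Statements on the series, on what has been measured and on what is new or still open speak of the compounds shown alone.

In a functional assay on MDA-MB-231 cells (Homo sapiens) for antiproliferative activity, read by MTT assay, with a stated time of 72 h (on this read-out lower numbers stand for stronger inhibition and higher numbers for weaker inhibition), compound 1 `CC(C)(C)NC(=O)CCc1cccc2c1B(O)OC2` gives only a limit, > 100000 nM. Compound 2 `O=C(CCc1cccc2c1B(O)OC2)Nc1nccs1` is also a limit, > 100000 nM. Among the compounds with values here, compound 3 `O=C(CCc1cccc2c1B(O)OC2)Nc1cccc(Br)c1` gives the only actual number so far, 720 nM, and stands as the strongest of the three. Its position rests on two measured steps: an at least 130-fold lower number from compound 1 to compound 3 (2.14 log units; beyond the scatter) and an at least 130-fold lower number from compound 2 to compound 3 (2.14 log units; beyond the scatter). Going by these compounds, both are large, yet both start from the limit of > 100000 nM in this assay, at which 2 of the 3 values shown sit, so their true size remains open.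

Compound 4 `CC(C)c1cccc(NC(=O)CCc2cccc3c2B(O)OC3)c1` carries isopropyl in place of bromo on an aromatic carbon, meta to a large group: isopropyl in place of bromo on an aromatic carbon. Both measured steps change the group on the amide-type nitrogen, and neither changes a substituent on the aromatic ring, so they give no direct size for this change. Within the data shown here, they show only that compound 3, at 720 nM, is the one measured compound with a substituted six-membered aromatic ring of carbon only on that nitrogen, and compound 4 keeps that ring. No large loss is therefore expected in this assay, and no step beyond the scatter is predicted. The estimated step is a 1.5-fold higher number from compound 3 to compound 4 (0.18 log units; within the scatter), with a slightly higher number expected if any shift appears. For compound 4 the estimated value is 1100 nM, with an expected range of 250 nM to 6000 nM.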

Compound 4, half-maximal inhibitory concentration: 1600 nM
Compound 4: middle estimate off by 1.5-fold (0.16 log units), on the low side, within the range that was stated.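

In this assay, the substituent on the aromatic carbon meta to a large group now has a readable effect of its own: a 2.2-fold higher number from compound 3 to compound 4 (0.35 log units; beyond the scatter), a modest change but one beyond the usual scatter. Compound 4 gives an actual number, so bromo is not required at this place for a measured value, and isopropyl, with 3 carbon atoms in place of 1 bromine atom, is accepted at a modest cost. Within the data shown here, this is also the first step with a number at both ends, whereas the earlier steps changed the group on the amide-type nitrogen and their true size stays open: the limit of > 100000 nM in this assay, at which 2 of the 4 values shown sit.

Going by these compounds, with only bromo and isopropyl at this place, two points do not yet show a trend, and it remains open how a methyl, a methoxy, an amine or a carboxylic acid would behave there. Also open, on these data alone, is whether bromo or isopropyl would give a similar step at another place on the ring, and whether a longer chain between the amide carbonyl and the shared core would keep the value of compound 3.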